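The source may report more compounds than this note shows. Statements on the series, on what has been measured and on what is new or still open speak of the compounds shown alone.

Compound 1 `CNc1nc(NC(C)(C)C)c2sc(-c3ccc(C(F)(F)F)cc3)cc2n1` sits at a limit of a physicochemical assay for solubility, in phosphate buffer, at pH 6.5 (on this read-out higher numbers stand for higher solubility and lower numbers for lower solubility), and gives < 1.6 ug/mL. Compound 2 `CNc1nc(NC2CC2)c2sc(-c3ccc(C(F)(F)F)cc3)cc2n1` also sits at a limit, giving < 5 ug/mL. For the measured compounds named here, compound 3 `CNc1nc(Nc2cccc(C(N)=O)c2)c2sc(-c3ccc(C(F)(F)F)cc3)cc2n1` is the only member of the three with an actual number in this assay, giving 8 ug/mL. The step of an at least 5.0-fold higher number from compound 1 to compound 3 (0.69 log units; beyond the scatter) is at least modest, the step of an at least 1.6-fold higher number from compound 2 to compound 3 (0.20 log units; that floor lies within the scatter) has a floor within the scatter, and the step that the two limits leave unreadable from compound 1 to compound 2 cannot be read because of the limit of < 1.6 ug/mL in this assay, at which 1 of the 3 values shown sits, and (the limit of < 5 ug/mL in this assay, at which 1 of the 3 values shown sits). Compound 4 `CNc1nc(Nc2cccc(S(C)(=O)=O)c2)c2sc(-c3ccc(C(F)(F)F)cc3)cc2n1` carries methylsulfonyl in place of carbamoyl on an aromatic carbon. Going by the values given here, none of the measured steps touches this position; all three swap the group on the nitrogen, so they only fix where compound 3 stands. The step expected in this assay is no change at the digits printed from compound 3 to compound 4 (within the scatter), nothing beyond the scatter. Compound 4 is therefore estimated at 8 ug/mL, with a range from 3 ug/mL to 20 ug/mL.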

Compound 4, solubility: < 5 ug/mL
Compound 4: only a limit was reported; the forecaster's own chance of this, stated with the estimate: 15%; middle value at least 1.6-fold (0.20 log units) away from the limit.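

Methylsulfonyl in place of carbamoyl is the first change at this position, and in this assay it gives an at least 1.6-fold lower number from compound 3 to compound 4 (0.20 log units; that floor lies within the scatter). Compound 4 has only a limit, so this floor, which lies within the scatter, does not settle whether the swap costs anything. The steps to compound 4 from compound 1 and from compound 2 each join two limits and cannot be read.

On these data alone, the actual size of the step from carbamoyl to methylsulfonyl remains open. Also open, as far as these compounds go, is how a carboxylic acid or an amine at this position would compare with compound 3 at 8 ug/mL.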